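Moving the chlorine on the pendant phenyl ring

A few compounds are considered here, and "the series" means these few. Any claim that something is new, unique, unknown or untested is made for them only; others in the source may bear on it.

Compound 1 `Oc1ccc(-c2cc(-c3cccnc3)nc(-c3ccccc3Cl)c2)cc1` has no single number in a functional assay on T47D cells (Homo sapiens) for cytotoxicity, read by CCK-8 assay and cell counting, with a stated time of 2 days; a lower number here means a stronger inhibitor, a higher number a weaker inhibitor; its entry there is "not determined" (no result reported). Two relatives of compound 1 share its core and its 2-chlorophenyl group but carry a different five-membered ring in the remaining position. Compound 2 `Oc1ccc(-c2cc(-c3cccs3)nc(-c3ccccc3Cl)c2)cc1` gives 5870 nM in this assay, and compound 3 `Oc1ccc(-c2cc(-c3ccco3)nc(-c3ccccc3Cl)c2)cc1` gives 5480 nM. Going by the values given here, the only measured step, a 1.1-fold lower number from compound 2 to compound 3 (0.03 log units; within the scatter), shows that exchanging those five-membered rings leaves the number where it was.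

Compound 4 `Oc1ccc(-c2cc(-c3ccc(Cl)cc3)nc(-c3cccnc3)c2)cc1` differs from compound 1 as follows: 4-chlorophenyl in place of 2-chlorophenyl on an aromatic carbon. Among the compounds with values here, no measured pair bears on this change, since the 2-chlorophenyl group is kept in every measured compound and compound 1 itself has no number. The step from compound 2 to compound 3 only shows that the core tolerates a change elsewhere without moving the read-out. Compound 4 is therefore expected to land near the numbers of compound 2 and compound 3, estimated at 6000 nM with a range from 1500 nM to 25000 nM.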

Compound 4, half-maximal inhibitory concentration: 29300 nM
Estimate against measurement, compound 4: 4.9-fold (0.69 log units) below, outside the stated range (above it).
By their numbers in this assay, from the lowest: compounds 3 and 2 (each within the scatter of the next); then compound 4.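

No new step can be read from compound 4: its one partner differing in one place is compound 1, and in this assay compound 1 gives "not determined" (no result reported). The compounds shown leave open what 4-chlorophenyl in place of 2-chlorophenyl does to the number. No data shown explain the result for compound 4.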